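Methoxy on the anilino ring: expected effect on edema

The source may report more compounds than this note shows. Statements on the series, on what has been measured and on what is new or still open speak of the compounds shown alone.

Compound 1, `CCOC(=O)c1c(-c2ccc(Cl)cc2)cc(-c2ccccc2)nc1Nc1ccccc1`, gives 73.7% in a functional assay on the whole organism (strain Wister albino) for inhibition, with Rattus norvegicus as the target, read by paw edema, with stated times of 1 h and 3 h, at a dose of 50 mg/kg by the intraperitoneal route; on this read-out higher numbers stand for more inhibition at the one dose given (going by the name of the read-out) and lower numbers for less inhibition. Going by the values given here, it is the higher of the two numbers measured so far; compound 2, `CCOC(=O)c1c(-c2ccc(Cl)c(Cl)c2)cc(-c2ccccc2)nc1Nc1ccc(C)cc1`, gives 59.3% in this assay, a value lower than that of compound 1 by more than the usual scatter. Compound 3, `CCOC(=O)c1c(-c2ccc(Cl)cc2)cc(-c2ccccc2)nc1Nc1ccc(OC)cc1`, is not yet measured. It differs from compound 1 by methoxy in place of hydrogen on an aromatic carbon. Among the compounds with values here, no step of this kind is known, so the expected step of a number 5.7 percentage points lower from compound 1 to compound 3 (within the scatter) is small and within the scatter, with a slight lean downward. Compound 3 is therefore estimated at 68%, in the range 50% to 82%.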

Compound 3, a percentage reported as inhibition, in the whole organism at one dose (the size of the read-out at that dose, not a potency): 68.8%
The estimate for compound 3 lay 0.8 percentage points below the measured number, and the stated range covers the measured number.
By their numbers in this assay, from the lowest: compounds 2, 3 and 1 (each within the scatter of the next, the first and the last beyond it).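

In this assay, going by these compounds alone, the change from anilino to (4-methoxyphenyl)amino gives a number 4.9 percentage points lower from compound 1 to compound 3 (within the scatter), the first step that isolates a single place. At this one dose, the position para to a large group therefore carries methoxy in place of hydrogen without a step beyond the scatter. No measurement among these data speaks to the reason for this result. A single methoxy step leaves open how an amine or a carboxylic acid at the same position would read, and whether a longer chain such as butoxy would stay within the scatter of compound 1.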